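This account rests on a few compounds, and the source may have more. Where it says the series, first, only, none or still open, it means among the compounds named here.

In a functional assay on SW-620 cells (Homo sapiens) for cytotoxicity, read by MTT assay, with a stated time of 72 h (a lower number here means a stronger inhibitor, a higher number a weaker inhibitor), the measured compounds read:

Compound 1 `COc1ccccc1/C=C1\CCC/C(=C\c2cccc(OC)c2OC)C1=O`: > 20000 nM (a limit of the assay, not a number)
Compound 2 `COc1cccc(/C=C2\CCC/C(=C\c3ccc(Cl)c(Cl)c3)C2=O)c1OC`: 10000 nM

Among the compounds with values here, compound 2 carries the only true number, 10000 nM. For compound 1 there is only (the limit of > 20000 nM in this assay, at which 1 of the 2 values shown sits).

Compound 3 `COc1cccc(/C=C2\CCC/C(=C\c3cc(Cl)cc(Cl)c3)C2=O)c1OC` departs from compound 2 in one place: 3,5-dichlorophenyl in place of 3,4-dichlorophenyl on a double-bonded chain carbon bound to a double-bonded ring carbon. The chlorine pattern shifts, so 3,5-dichlorophenyl replaces 3,4-dichlorophenyl.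

Within the data shown here, one measured step touches that same place, an at least 2.0-fold lower number from compound 1 to compound 2 (0.30 log units; that floor lies within the scatter). It exchanged a different group, and its floor lies within the scatter, so it gives no size to carry over. Among the measured compounds shown here, no measured step compares the two dichlorophenyl patterns. No change beyond the scatter is therefore expected in this assay.

The estimated step is no change at the digits printed from compound 2 to compound 3 (within the scatter).

Compound 3 is estimated at 10000 nM, with an expected range from 4000 nM to 20000 nM.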

Compound 3, half-maximal inhibitory concentration: 5500 nM
Estimate against measurement, compound 3: 1.8-fold (0.26 log units) above; the range from low to high includes it.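

In this assay, exchanging 3,4-dichlorophenyl for 3,5-dichlorophenyl on a double-bonded chain carbon bound to a double-bonded ring carbon gives a 1.8-fold lower number from compound 2 to compound 3 (0.26 log units; within the scatter), so the two chlorine patterns cannot be told apart here. Against 2-methoxyphenyl at the same place, 3,5-dichlorophenyl gives an at least 3.6-fold lower number from compound 1 to compound 3 (0.56 log units; beyond the scatter), the first step at this position that clears the scatter, although its size remains only a floor. Compound 1 supplies a limit of the assay, not a number: the limit of > 20000 nM in this assay, at which 1 of the 3 values shown sits.

The compounds shown leave open whether a phenyl ring with a single chlorine, a trifluoromethyl group or a dimethylamino group would read differently at this position. They also leave open whether changes on the other side of the shared core would alter these readings.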